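From ethoxy to benzyloxy: compound 3 to compound 4

The source may hold more compounds than are shown below. What is called first, only, known or untested is meant among the compounds shown, and "the series" means these compounds.

Measured so far in a functional assay on thoracic aorta (Rattus norvegicus, strain Wistar), with a stated time of 15 min; a higher number here means that more compound is needed for the effect, a lower number that less compound is needed:
compound 1 `CC(NC(=O)NS(=O)(=O)c1ccc(Cl)cc1)c1cc(Br)ccc1OCc1ccccc1`: 57500 nM
compound 2 `Cc1ccc(S(=O)(=O)N(C)C(=O)NC(C)c2cc(Br)ccc2OCc2ccccc2)cc1`: 67100 nM
compound 3 `CCOc1ccc(Br)cc1C(C)NC(=O)N(C)S(=O)(=O)c1ccc(Cl)cc1`: 55700 nM

A smaller number in this assay means that less compound is needed for the effect. Compound 3, at 55700 nM, lies within the usual scatter of both compound 1 and compound 2, so these three values cannot be ranked.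

The next structure is compound 4 `CC(NC(=O)N(C)S(=O)(=O)c1ccc(Cl)cc1)c1cc(Br)ccc1OCc1ccccc1`. Compared with compound 3 it shows this change: phenyl in place of methyl on a saturated chain carbon bound to an oxygen on an aromatic ring. In words, the ethoxy of compound 3 becomes benzyloxy in compound 4.

Among the measured compounds shown here, no measured pair isolates this change, so the evidence is indirect. Benzyloxy is already present in compound 1 at 57500 nM and in compound 2 at 67100 nM, and both values are within the scatter of compound 3. No change beyond the scatter is therefore expected. The estimate means a 1.1-fold higher number from compound 3 to compound 4 (0.03 log units; within the scatter), which is expected to stay within the scatter. For compound 4 the estimated value is 60000 nM, with an expected range from 32000 nM to 110000 nM.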

Compound 4, half-maximal effective concentration: 146000 nM
For compound 4 the middle estimate is 2.4-fold (0.39 log units) below the measured one; the whole stated range lies below it.
By their numbers in this assay, from the lowest: compounds 3, 1 and 2 (each within the scatter of the next); then compound 4.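

In this assay, the change from ethoxy to benzyloxy is not silent when the rest of the molecule is that of compound 3, giving a 2.6-fold higher number from compound 3 to compound 4 (0.42 log units; beyond the scatter). Benzyloxy alone does not decide the value, since compound 1 and compound 2 also carry it: methyl in place of hydrogen on an amide-type nitrogen gives a 2.5-fold higher number from compound 1 to compound 4 (0.40 log units; beyond the scatter), and chloro in place of methyl on an aromatic carbon gives a 2.2-fold higher number from compound 2 to compound 4 (0.34 log units; beyond the scatter), so compound 4 needs the most compound of the four and the effect of this change depends on its surroundings. Nothing measured on these compounds accounts for these rises.

From the compounds shown here alone, whether ethoxy to benzyloxy would act the same way with the amide hydrogen in place of that methyl stays open. Also open, going by these compounds, is how a methoxy group, a longer alkoxy chain or a chain ending in an amine would read at this place.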